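A few compounds are considered here, and "the series" means these few. Any claim that something is new, unique, unknown or untested is made for them only; others in the source may bear on it.

Measured so far:
- Compound 2, `C/N=C1\S/C(=C\c2cc(C)n(Cc3ccccc3)c2C)C(=O)N1C`: in a functional assay for agonist activity at sphingosine 1-phosphate receptor 5 (Homo sapiens) (on this read-out lower numbers stand for an effect already at smaller amounts and higher numbers for an effect only at larger amounts of compound), compound 2 gives 144 nM.
- Compound 1, `COCC/N=C1\S/C(=C\c2cc(C)n(-c3ccc(F)cc3F)c2C)C(=O)N1C`: in this assay compound 1 gives 2100 nM.

Of these two, compound 2 stands at the lower number, and its gap to compound 1 lies beyond the usual scatter. Compound 1 and compound 2 differ in two places at once, so the two numbers cannot be traced to either change alone.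

Compound 3, `COCC/N=C1\S/C(=C\c2cc(C)n(Cc3ccccc3)c2C)C(=O)N1C`, is not yet measured. It keeps the shared core of compound 2 and changes it in one way: methoxymethyl in place of hydrogen on a saturated chain carbon bound to a double-bonded nitrogen. Among the measured compounds shown here, no measured pair shows this change on its own. Since compound 1, which carries that same methoxymethyl, gives a higher number while also differing elsewhere, the expected step from compound 2 to compound 3 is estimated as a modest rise, a 2.1-fold higher number from compound 2 to compound 3 (0.32 log units; beyond the scatter), possibly within the scatter. Compound 3 is therefore expected to give about 300 nM, in a range from 100 nM to 1000 nM.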

Compound 3, half-maximal effective concentration: 196 nM
For compound 3 the middle estimate is 1.5-fold (0.18 log units) above the measured one, and the stated range covers the measured number.
By their numbers in this assay, from the lowest: compounds 2 and 3 (each within the scatter of the next); then compound 1.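

In this assay, methoxymethyl in place of hydrogen on the saturated chain carbon bound to the double-bonded nitrogen gives a 1.4-fold higher number from compound 2 to compound 3 (0.13 log units; within the scatter), so this position accepts the larger group with no change beyond the scatter. With that group kept, benzyl in place of 2,4-difluorophenyl on the aromatic nitrogen gives an 11-fold lower number from compound 1 to compound 3 (1.03 log units; beyond the scatter) and thus shows, on its own, a large effect of this change. No data here explain either step. On these data alone, whether an amine or a carboxylic acid on that chain would be accepted as well remains open, as does the effect of a 2-phenylethyl group on the aromatic nitrogen.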